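The source may hold more compounds than are shown below. What is called first, only, known or untested is meant among the compounds shown, and "the series" means these compounds.

Of the compounds shown here, three built on a shared core have been measured in an ADME assay on microsomes from liver (Homo sapiens) for metabolic stability, read by LC-MS, using NADPH, with a stated time of 45 min, tested at 1 uM; on this read-out higher numbers stand for a longer-lived compound and lower numbers for a shorter-lived compound. Compound 3 `Cc1cc(/C=C/C#N)cc(C)c1Oc1cc(Nc2ccc(C#N)cc2)c(N)cc1C(=O)N1CC1` gives 2.63 h, the highest of the three numbers. Compound 1 `Cc1cc(/C=C/C#N)cc(C)c1Oc1cc(Nc2ccc(C#N)cc2)c(N)cc1C(=O)NN` gives 0.6 h, and compound 2 `Cc1cc(/C=C/C#N)cc(C)c1Oc1cc(Nc2ccc(C#N)cc2)c(N)cc1C(=O)NCCC(F)F` gives 0.233 h. The step of a 4.4-fold higher number from compound 1 to compound 3 (0.64 log units; beyond the scatter) and the step of an 11-fold higher number from compound 2 to compound 3 (1.05 log units; beyond the scatter) both rise, while the step of a 2.6-fold lower number from compound 1 to compound 2 (0.41 log units; beyond the scatter) falls.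

Compound 4 `CNC(=O)c1cc(N)c(Nc2ccc(C#N)cc2)cc1Oc1c(C)cc(/C=C/C#N)cc1C` has not yet been measured in this assay. It differs from compound 3 by methylamino in place of aziridin-1-yl on a carbonyl carbon. The step that bears most directly on this change is an 11-fold higher number from compound 2 to compound 3 (1.05 log units; beyond the scatter), in which (3,3-difluoropropyl)amino on the carbonyl carbon gave way to aziridin-1-yl; the step of a 4.4-fold higher number from compound 1 to compound 3 (0.64 log units; beyond the scatter) points the same way. Read in reverse, both suggest that replacing aziridin-1-yl with methylamino should lower the number, though no measured step shows methylamino itself, so the account expects a modest downward step, a 3.8-fold lower number from compound 3 to compound 4 (0.57 log units; beyond the scatter). Compound 4 is therefore estimated at 0.7 h, with a range from 0.3 h to 1.8 h.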

Compound 4, half-life: 1.87 h
Estimate against measurement, compound 4: 2.7-fold (0.43 log units) below, and the stated range ends below it.
By their numbers in this assay, from the lowest: compound 2; then compound 1; then compounds 4 and 3 (each within the scatter of the next).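

The step of a 1.4-fold lower number from compound 3 to compound 4 (0.15 log units; within the scatter) in this assay shows that on this carbonyl carbon the ring-free methylamino, with one hydrogen-bond donor, gives a number within the scatter of aziridin-1-yl, which has no ring-opened form and no such donor; the ring is thus not required for a number in this range. Methylamino also stands clear of the other two groups, with an 8.0-fold higher number from compound 2 to compound 4 (0.90 log units; beyond the scatter) and a 3.1-fold higher number from compound 1 to compound 4 (0.49 log units; beyond the scatter) so the low numbers of compound 1 and compound 2 do not belong to every amide that keeps its hydrogen. Nothing measured here explains these differences.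

The compounds shown leave open how the number runs along a plain ethyl or propyl chain without fluorine. They also leave open what dimethylamino or azetidin-1-yl would give on this carbonyl carbon.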